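Swapping an aromatic ring for a benzyloxy group

The source may report more compounds than this note shows. Statements on the series, on what has been measured and on what is new or still open speak of the compounds shown alone.

Two compounds share one core and are compared in a functional assay on HEK293 cells for antagonist activity at Orexin receptor type 2 (Homo sapiens), read by FLIPR and calcium flux; on this read-out higher numbers stand for higher potency (the scale is a negative logarithm) and lower numbers for lower potency. Compound 1 `Cc1cnn(-c2ccc(C)nc2C(=O)N2CC3(CC3)C[C@H]2CNc2ccc(C(F)(F)F)cn2)c1` gives 8.3 in this assay. Compound 2 `Cc1ccc(-c2nccs2)c(C(=O)N2CC3(CC3)C[C@H]2CNc2ccc(C(F)(F)F)cn2)n1` gives 8 in this assay. Going by the values given here, the only measured step, a number 0.30 log units lower from compound 1 to compound 2 (within the scatter), is within the scatter, so the two compounds cannot be ranked; compound 2 simply has the lower of the two numbers, with compound 1 as its only neighbour.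

Compound 3 `Cc1ccc(OCc2ccccc2)c(C(=O)N2CC3(CC3)C[C@H]2CNc2ccc(C(F)(F)F)cn2)n1` is not yet measured. It differs from compound 2 in one place: benzyloxy in place of 1,3-thiazol-2-yl on an aromatic carbon. The measured step bears on this change only loosely, since it exchanged one five-membered aromatic ring with hetero atoms for another of the same kind, whereas here a benzyloxy group with a six-membered ring of carbon only enters. That earlier step was within the scatter, which hints that this position tolerates some variation, but the new group is of a different size and shape, so the outcome is uncertain. The expected step is a number 0.40 log units lower from compound 2 to compound 3 (beyond the scatter), leaning towards a modest loss. Compound 3 is therefore estimated at 7.6, with a range from 6.9 to 8.3.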

Compound 3, negative logarithm of the antagonist equilibrium constant: 8.6
The estimate for compound 3 lay 1.00 log units below the measured number, and the stated range ends below it.
By their numbers in this assay, from the lowest: compounds 2, 1 and 3 (each within the scatter of the next, the first and the last beyond it).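

In this assay, the place ortho to a large group on the shared core is not limited to five-membered aromatic rings with hetero atoms. Benzyloxy, with its oxygen and its six-membered aromatic ring of carbon only, in place of 1,3-thiazol-2-yl gives a number 0.60 log units higher from compound 2 to compound 3 (beyond the scatter), the first step in this set that lies beyond the scatter. Set against the 4-methyl-1H-pyrazol-1-yl group, the same benzyloxy gives a number 0.30 log units higher from compound 1 to compound 3 (within the scatter), so those two groups cannot be ranked, and a ring attached directly to the core is evidently not needed for a high number here. No supporting data are available to explain the gain over the 1,3-thiazol-2-yl group.

From the compounds shown here alone, it remains open whether the oxygen or the carbon-only ring accounts for the step, and a plain methoxy group and a directly attached phenyl ring would help to separate the two. Going by these compounds, it is equally open whether a longer chain between the oxygen and the ring, or an amine on that ring, would keep the number where it stands.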